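The source may report more compounds than this note shows. Statements on the series, on what has been measured and on what is new or still open speak of the compounds shown alone.

The measured compounds and their values:

compound 1, `COc1ccc(C2N=C(SCc3ccc(Cl)cc3)NC(C)=C2C(=O)Nc2ccc(F)cc2)cc1OC`: 10.3%
compound 2, `COc1ccc(C2N=C(SCc3ccc(F)cc3)NC(C)=C2C(=O)Nc2ccc(F)cc2)cc1OC`: 11.8%
compound 3, `COc1ccc(C2N=C(SCc3ccc(Cl)cc3)NC(C)=C2C(=O)Nc2ccc(Br)cc2)cc1`: 12.3%

All three were examined in a functional assay on the whole organism (artery, strain albino) with Rattus norvegicus as the target, with a stated time of 60 min, at a dose of 10 mg/kg by the oral route; on this read-out lower numbers stand for less inhibition and higher numbers for more inhibition at the one dose given (going by the name of the read-out). Compound 1, `COc1ccc(C2N=C(SCc3ccc(Cl)cc3)NC(C)=C2C(=O)Nc2ccc(F)cc2)cc1OC`, gives 10.3% in this assay, and compound 2, `COc1ccc(C2N=C(SCc3ccc(F)cc3)NC(C)=C2C(=O)Nc2ccc(F)cc2)cc1OC`, gives 11.8%. These two differ in one place, (fluoro in place of chloro on an aromatic carbon), and the measured step is a number 1.5 percentage points higher from compound 1 to compound 2 (within the scatter), so the two numbers cannot be told apart within this assay. Compound 3, `COc1ccc(C2N=C(SCc3ccc(Cl)cc3)NC(C)=C2C(=O)Nc2ccc(Br)cc2)cc1`, gives 12.3% in this assay; its value sits close to those of compound 1 and compound 2, and none of the three can be ranked against the others. The difference between the core of compound 3 and the core of compound 1 is not broken down here.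

Compound 4, `COc1ccc(C2N=C(SCc3ccc(F)cc3)NC(C)=C2C(=O)Nc2ccc(Br)cc2)cc1`, has not yet been measured. It stands to compound 3 as compound 2 stands to compound 1, with the difference (fluoro in place of chloro on an aromatic carbon); the place of the change reads the same in both pairs, so this is the same change applied to a second core. Because the earlier step was a number 1.5 percentage points higher from compound 1 to compound 2 (within the scatter), the expected step from compound 3 to compound 4 is likewise small, about a number 1.2 percentage points higher from compound 3 to compound 4 (within the scatter), with all three measured values lying low and within the scatter of one another. Compound 4 is therefore estimated at 13.5% in this assay, with a likely range from 5% to 24%.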

Compound 4, a percentage reported as inhibition, in the whole organism at one dose (the size of the read-out at that dose, not a potency): 8.7%
Compound 4: the middle estimate sits 4.8 percentage points above what was measured, within the range that was stated.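

In this assay, the exchange of 4-chlorobenzyl for 4-fluorobenzyl gives a number 3.6 percentage points lower from compound 3 to compound 4 (within the scatter) on the core of compound 3, and set beside the same exchange on the core of compound 1, the two steps cannot be told apart: the same change on two cores in this assay, a number 1.5 percentage points higher (within the scatter) from compound 1 to compound 2 and a number 3.6 percentage points lower (within the scatter) from compound 3 to compound 4, 5.1 percentage points apart, within the scatter of two such steps. This shows that on both cores the change moves the read-out by no more than the usual scatter, and that nothing in these two pairs separates the way the two cores respond to it. It does not show that the change carries a fixed size or direction from one core to another, since the two steps point opposite ways but are too small to be read, nor does it show that the two cores would respond alike to a change with a larger step.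

The compounds shown leave open whether a nitrile or a carboxylic acid in place of the halogen on the benzyl ring, or a longer alkyl chain in place of the whole benzyl group, would move the read-out beyond the scatter. They also leave open whether the fluoro and chloro pairs would separate at another dose or at another time after dosing.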